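The source may report more compounds than this note shows. Statements on the series, on what has been measured and on what is new or still open speak of the compounds shown alone.

Measured in an ADME assay on BJ cells (Homo sapiens) for cytotoxicity, read by CellTiter-Glo and resazurin assay, with a stated time of 72 h (a higher number here means that more compound is needed for the effect, a lower number that less compound is needed), each value a limit:
- compound 1 `Cc1nnc(-c2cccc(-c3ccc(C(=O)N(Cc4cccc(OCCCCCC(=O)O)c4)C(C)C)cc3)c2)o1`: > 26000 nM
- compound 2 `CC(C)N(Cc1cccc(OCCCCCC(=O)O)c1)C(=O)c1ccc(-c2cccc(O)c2)cc1`: > 26000 nM
- compound 3 `COc1ccc(F)c(-c2ccc(C(=O)N(Cc3cccc(OCCCCCC(=O)O)c3)C(C)C)cc2)c1`: > 26000 nM

Compound 3 gives no number, only the limit > 26000 nM. It cannot be ranked against the other two compounds.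

Compound 4 `CC(C)N(Cc1cccc(OCCCCCC(=O)O)c1)C(=O)c1ccc(-c2cccc(S(C)(=O)=O)c2)cc1` carries 3-(methylsulfonyl)phenyl in place of 2-fluoro-5-methoxyphenyl on an aromatic carbon, para to a large group: 3-(methylsulfonyl)phenyl in place of 2-fluoro-5-methoxyphenyl on an aromatic carbon.

Three measured steps change this same substituent: a step that the two limits leave unreadable from compound 1 to compound 2, a step that the two limits leave unreadable from compound 1 to compound 3 and a step that the two limits leave unreadable from compound 2 to compound 3. None of them has a readable size, and none gives a direction. The expectation for compound 4 therefore rests on (the limit of > 26000 nM in this assay, at which 3 of the 3 values shown sit). In this assay no step beyond the scatter is expected, and a report of only a limit is the likely outcome. The expected step is a step that the limit leaves unreadable from compound 3 to compound 4. The estimate for compound 4 is 30000 nM, with an expected range of 18000 nM to 60000 nM.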

Compound 4, half-maximal effective concentration: > 26000 nM
Compound 4: no number, only a limit; the forecaster's own chance of this, stated with the estimate: 85%; the middle value is on the limit's open side.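

Among the compounds shown here, compound 4 gives > 26000 nM in this assay, a limit and not a number, so no step among compound 1, compound 2, compound 3 and compound 4 can be read. The compounds shown leave open whether any substituent at this place gives a readable value in this assay: the limit of > 26000 nM in this assay, at which 4 of the 4 values shown sit.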